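Methyl for Cyclohexyl on the Core Nitrogen

This account rests on a few compounds, and the source may have more. Where it says the series, first, only, none or still open, it means among the compounds named here.

Compound 1, `CC(=O)Nc1ccc(-c2nc3cc(C(F)(F)F)ccc3n2C2CCCCC2)cc1`, gives 30000 nM in an ADME assay on Vero cells (Chlorocebus sabaeus) for cytotoxicity; a lower number here means that less compound is tolerated, a higher number that more compound is tolerated.
Compound 2, `O=[N+]([O-])c1ccc(-c2nc3cc(Cl)c(Cl)cc3[nH]2)cc1`, reaches only the limit >= 100000 nM in this assay.
Compound 3, `COc1ccc(-c2nc3cc(Cl)c(Cl)cc3[nH]2)cc1`, gives 30000 nM in this assay.

Compound 1 stands level with compound 3 at the digits shown, within the scatter, while compound 2 sits at the limit of >= 100000 nM in this assay, at which 1 of the 3 values shown sits. Going by the values given here, the one measured step, an at least 3.3-fold lower number from compound 2 to compound 3 (0.52 log units; beyond the scatter), changes a group on an aromatic carbon and does not touch the ring nitrogen, so it gives no direct guide to the change from compound 1 to compound 4, `CC(=O)Nc1ccc(-c2nc3cc(C(F)(F)F)ccc3n2C)cc1`: methyl in place of cyclohexyl on an aromatic nitrogen. Among the compounds with values here, no measured step speaks to this position. Compound 4 is therefore expected to stay within the scatter of compound 1, a 1.3-fold higher number from compound 1 to compound 4 (0.12 log units; within the scatter), with an estimated 40000 nM between 15000 nM and 100000 nM.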

Compound 4, half-maximal cytotoxic concentration: > 100000 nM
Compound 4 was reported as a limit (the forecaster's own chance of this, stated with the estimate: 30%); middle value at least 2.5-fold (0.39 log units) from the limit.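

At this aromatic nitrogen the choice of group clearly matters in this assay: methyl in place of cyclohexyl gives an at least 3.3-fold higher number from compound 1 to compound 4 (0.52 log units; beyond the scatter). Going by these compounds alone, the earlier compounds offered only a step on an aromatic carbon, so this is the first measured sign that the ring nitrogen's group counts as well. The full size of the step stays unknown because the value of compound 4 is a limit: the limit of > 100000 nM in this assay, at which 1 of the 4 values shown sits.

From the compounds shown here alone, how an ethyl group, a longer chain or a cyclopropyl ring on this nitrogen would compare remains open. So does whether the step holds with other groups on the shared core.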